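This account rests on a few compounds, and the source may have more. Where it says the series, first, only, none or still open, it means among the compounds named here.

Compound 3 `Cc1cc(=O)oc2cc(SCc3cccc(C(F)(F)F)c3)ccc12` was examined in a functional assay on DU-145 cells (Homo sapiens) for antiproliferative activity, read by sulforhodamine B assay, with a stated time of 72 h; a higher number here means a weaker inhibitor of growth, a lower number a stronger inhibitor of growth. In this assay compound 3 gives > 28500 nM, which is a limit of the assay rather than a number. Compound 1 `Cc1cc(=O)oc2cc(SCc3ccccn3)ccc12` gives > 35200 nM, also a limit. Compound 2 `Cc1cc(=O)oc2cc(SCc3cccnc3)ccc12` gives > 35200 nM, again a limit. Going by the values given here, the single step between compounds differing in one place, a step that the two limits leave unreadable from compound 1 to compound 2, cannot be read in size or direction. Compound 4 `COC(=O)c1cccc(CSc2ccc3c(C)cc(=O)oc3c2)c1` differs from compound 3 by methoxycarbonyl in place of trifluoromethyl on an aromatic carbon. Among the compounds with values here, no measured step bears on this change, and every value shown sits at a limit, as the limit of > 28500 nM in this assay, at which 1 of the 3 values shown sits, and the limit of > 35200 nM in this assay, at which 2 of the 3 values shown sit, make plain, so neither size nor direction can be drawn from them. Compound 4 is therefore expected to remain near the limit, the estimated step being a step that the limit leaves unreadable from compound 3 to compound 4 and the estimate 35000 nM with a range from 8000 nM to 100000 nM.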

Compound 4, concentration for 50% growth inhibition: 14100 nM
Compound 4: middle estimate off by 2.5-fold (0.39 log units), on the high side, and the stated range covers the measured number.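

In this assay compound 4 is the first of the compounds shown to give a number rather than a limit of the assay, so this position on the aromatic ring now has a readable value. Methoxycarbonyl in place of trifluoromethyl amounts to an at least 2.0-fold lower number from compound 3 to compound 4 (0.30 log units; that floor lies within the scatter). Going by these compounds, the true size of this step remains unknown, and its floor alone does not separate it from the scatter.

On these data alone, what a carboxylic acid or an amide at this same aromatic carbon would give stays open. So does whether a longer chain in place of the methyl of methoxycarbonyl would lower the number further.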